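The compounds below may be only part of what the source reports. "The series", "measured", "known", "first", "only" and "open" are said of these compounds alone.

Measured compounds in a functional assay on WiDr cells (Homo sapiens) for inhibition, read by sulforhodamine B assay, with a stated time of 48 h; on this read-out higher numbers stand for weaker inhibition of growth and lower numbers for stronger inhibition of growth:
compound 1 `COC(=O)[C@@]1(C)CCC=C2[C@@H]1CC[C@@H](C)[C@]2(C)Cc1c[nH]c2ccccc12`, 8700 nM
compound 2 `COC(=O)[C@@]1(C)CCC=C2[C@@H]1CC[C@@H](C)[C@]2(C)Cc1c(C)[nH]c2ccccc12`, 19000 nM

Compound 2 stands highest of the two numbers in this assay; the nearest is compound 1, and the step of a 2.2-fold higher number from compound 1 to compound 2 (0.34 log units; beyond the scatter) separates them. Compound 3 `COC(=O)[C@@]1(C)CCC=C2[C@@H]1CC[C@@H](C)[C@]2(C)Cc1c(C)[nH]c2ccc(OC)cc12` is not yet measured. It differs from compound 2 by methoxy in place of hydrogen on an aromatic carbon, sited on an aromatic carbon of a six-membered aromatic ring of carbon only, part of a fused system of two rings, meta to a fused ring and para to a fused ring. Going by the values given here, the single measured step, a 2.2-fold higher number from compound 1 to compound 2 (0.34 log units; beyond the scatter), concerns a different change, a methyl on an aromatic carbon, and bears on the present one only as a reminder that a small addition to this part of the core moved the number modestly. Among the compounds with values here, no measured pair carries a methoxy for hydrogen, so no direction is indicated. For compound 3 a step of about no change at the digits printed from compound 2 to compound 3 (within the scatter) is expected, that is nothing beyond the scatter. Compound 3 is estimated at 19000 nM, range 8000 nM to 45000 nM.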

Compound 3, concentration for 50% growth inhibition: 17000 nM
Compound 3: the middle estimate sits 1.1-fold (0.05 log units) above what was measured; the range from low to high includes it.
By their numbers in this assay, from the lowest: compounds 1, 3 and 2 (each within the scatter of the next, the first and the last beyond it).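

In this assay methoxy in place of hydrogen on an aromatic carbon gives a 1.1-fold lower number from compound 2 to compound 3 (0.05 log units; within the scatter) at this position, meta to a fused ring and para to a fused ring, so the added group is carried here with no difference beyond the scatter. Going by these compounds alone, the only earlier step, a 2.2-fold higher number from compound 1 to compound 2 (0.34 log units; beyond the scatter) for a methyl on a different aromatic carbon, lay beyond the scatter, whereas this substitution stays within it. No measurement on hand offers an explanation for this result.

On these data alone, whether the same position carries an amine, a carboxylic acid or a longer chain such as ethoxy with a similar result remains open. As far as these compounds go, the methoxy step is read only with the added methyl in place, so its size on the core of compound 1 is also open.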